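Pyridine to phenyl on the amide nitrogen of compound 2

The compounds below may be only part of what the source reports. "The series", "measured", "known", "first", "only" and "open" are said of these compounds alone.

Of the compounds shown here, two have been measured in an assay on isolated protein for inhibition of histone acetyltransferase p300 (Homo sapiens), with a stated time of 60 min; a higher number here means a weaker inhibitor, a lower number a stronger inhibitor. Compound 1, `COc1ccc(NC(=O)[C@H]2CCCN2C(=O)C(C)(C)c2ccc(Cl)cc2)cc1`, gives 50.1 nM in this assay. Compound 2, `COc1ccc(NC(=O)[C@H]2CCCN2C(=O)C2(c3cccc(Cl)c3)CCCC2)nc1`, gives 2 nM in this assay, the lowest of the two numbers; the gap between compound 1 and compound 2 lies beyond the scatter, but the two compounds differ in more than one place, so no single change can be credited with it.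

Compound 3, `COc1ccc(NC(=O)[C@H]2CCCN2C(=O)C2(c3cccc(Cl)c3)CCCC2)cc1`, is the next compound to be measured in this assay. Its change from compound 2 is 4-methoxyphenyl in place of 5-methoxypyridin-2-yl on an amide-type nitrogen. Within the data shown here, no measured pair isolates this change; compound 1 carries the 4-methoxyphenyl group but also differs from compound 2 elsewhere. The step is therefore expected to be a modest weakening, a 2.5-fold higher number from compound 2 to compound 3 (0.40 log units; beyond the scatter), with a real chance that it stays within the scatter. For compound 3 the expected value in this assay is 5 nM, with a range from 1.5 nM to 20 nM.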

Compound 3, half-maximal inhibitory concentration: 100 nM
Beside the measured number, compound 3's estimate is 20-fold (1.30 log units) below it; measured number above the stated range.
By their numbers in this assay, from the lowest: compound 2; then compounds 1 and 3 (each within the scatter of the next).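

In this assay, the exchange of 5-methoxypyridin-2-yl for 4-methoxyphenyl on the amide-type nitrogen gives a 50-fold higher number from compound 2 to compound 3 (1.70 log units; beyond the scatter), and this is the first pair shown in which this position alone varies. The step is large and beyond the scatter, so this position is not indifferent to the identity of its aromatic ring, even though the two groups have the same number of heavy atoms and the entering ring differs by being carbon only, with fewer hydrogen-bond acceptors. Nothing measured here explains the size of this step.

Going by these compounds, whether the low number of compound 2 depends on the ring nitrogen itself or would also hold for a pyrimidin-2-yl group or a 5-ethoxypyridin-2-yl group on the amide-type nitrogen stays open. On these data alone, it is equally open whether the same exchange would bring a step of similar size when the rest of the molecule is that of compound 1.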